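This account rests on a few compounds, and the source may have more. Where it says the series, first, only, none or still open, it means among the compounds named here.

Compound 1 `O=c1cc(Cn2cc(CCCCl)nn2)c2ccc(O)cc2o1` gives 59800 nM in a functional assay on SW-620 cells (Homo sapiens) for inhibition, read by MTT assay, with a stated time of 72 h; on this read-out lower numbers stand for stronger inhibition and higher numbers for weaker inhibition. Compound 2 `CC(O)c1cn(Cc2cc(=O)oc3cc(O)ccc23)nn1` reaches only a limit in this assay, > 100000 nM. Among the numbers shown, compound 2 thus stands at the limit itself (the limit of > 100000 nM in this assay, at which 1 of the 2 values shown sits), and the step of an at least 1.6-fold higher number from compound 1 to compound 2 (0.22 log units; that floor lies within the scatter) sets only a floor. Compound 3 `O=c1cc(Cn2cc(CCCCO)nn2)c2ccc(O)cc2o1` differs from compound 2 by a single change: 4-hydroxybutyl in place of 1-hydroxyethyl on an aromatic carbon. For the measured compounds named here, only the step from compound 1 to compound 2 bears on this change, and since it is a floor lying within the scatter, no direction beyond the scatter can be read from it. The 4-hydroxybutyl chain of compound 3 matches the 3-chloropropyl chain of compound 1 in length, and compound 1 gave 59800 nM, so a measurable number is expected rather than a limit. Compound 3 is therefore estimated at 80000 nM in this assay, with a range from 30000 nM to 200000 nM. This estimate implies an expected step of an at least 1.2-fold lower number from compound 2 to compound 3 (0.09 log units; that floor lies within the scatter) that may itself be no more than the scatter.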

Compound 3, half-maximal inhibitory concentration: > 100000 nM
Compound 3 ended at the assay's limit (the forecaster's own chance of this, stated with the estimate: 45%); middle value at least 1.2-fold (0.09 log units) from the limit.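

In this assay compound 3 also stands at a limit, > 100000 nM, and not at a number. Compound 1 therefore remains the only one of the three with a measured number, and hydroxymethyl in place of its chloro gives an at least 1.6-fold higher number from compound 1 to compound 3 (0.22 log units; that floor lies within the scatter), so this change sets only a floor and shows no direction beyond the scatter. With 1-hydroxyethyl and 4-hydroxybutyl on the aromatic carbon, the step between compound 2 and compound 3 cannot be read, and neither chain can be ranked over the other: the limit of > 100000 nM in this assay, at which 2 of the 3 values shown sit.

As far as these compounds go, it remains open whether the chloro of compound 1 matters to its measured number, given that the floor lies within the scatter. How an amine or a carboxylic acid in place of the hydroxyl on this chain would read, or a longer chain, cannot be told from these three compounds.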